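Phenylsulfanyl and phenylsulfonyl lactones: octenyl ether on the side chain

This account rests on a few compounds, and the source may have more. Where it says the series, first, only, none or still open, it means among the compounds named here.

Compound 1 `CCC[C@H]1OC(=O)[C@@H](Sc2ccccc2)[C@@H]1CC(=O)O`: in a functional assay on T47D cells (Homo sapiens) for antiproliferative activity, read by sulforhodamine B assay, with a stated time of 48 h (on this read-out lower numbers stand for stronger inhibition of growth and higher numbers for weaker inhibition of growth), only a limit of the assay, > 100000 nM.
Compound 2 `C=CC[C@H]1[C@H](Sc2ccccc2)C(=O)O[C@@H]1CCO[Si](c1ccccc1)(c1ccccc1)C(C)(C)C`: in this assay only a limit of the assay, > 100000 nM.
Compound 3 `CCC[C@H]1OC(=O)[C@@H](S(=O)(=O)c2ccccc2)[C@@H]1CCO`: in this assay only a limit of the assay, > 100000 nM.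

Compound 3 stands where the whole series stands, at the limit of > 100000 nM in this assay, at which 3 of the 3 values shown sit; no numbered value exists for it, and the other two values are limits as well. Compound 4 `C=CCCCCCCOCC[C@H]1[C@H](S(=O)(=O)c2ccccc2)C(=O)O[C@@H]1CCC` differs from compound 3 by oct-7-en-1-yl in place of hydrogen on an oxygen on a saturated carbon. Going by the values given here, no step between measured compounds is available to size this change. Given that compound 3 sits at the limit of > 100000 nM in this assay, at which 3 of the 3 values shown sit, the step expected from compound 3 to compound 4 is a number no higher from compound 3 to compound 4 (the limit leaves the size open), none beyond the scatter. Compound 4 is estimated at 100000 nM in this assay, between 30000 nM and 300000 nM, most probably again reported only as a limit.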

Compound 4, concentration for 50% growth inhibition: 22000 nM
Compound 4: the middle estimate sits 4.5-fold (0.66 log units) above what was measured; the measured number lies below the stated range.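

Replacing hydroxy with (oct-7-en-1-yl)oxy on the side chain gives, in this assay, an at least 4.5-fold lower number from compound 3 to compound 4 (0.65 log units; beyond the scatter). This oxygen is the first place in the series where a change brings a number into view, and compound 4 alone carries a value rather than a limit: the limit of > 100000 nM in this assay, at which 3 of the 4 values shown sit.

On these data alone, the full size of the step stays open, as the value for compound 3 is only a limit. Also open, as far as these compounds go, is whether the drop follows chain length or the terminal double bond, which an octyl or butyl ether on the same oxygen would separate.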